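The compounds below may be only part of what the source reports. "The series", "measured", "known", "first", "only" and "open" are said of these compounds alone.

Compound 1 `CN(C[C@H]1Cc2c(cccc2N2CCN(C3COC3)CC2)CN1)[C@H]1CCCc2cccnc21`: in a functional assay on CCRF-CEM cells for agonist activity at C-X-C chemokine receptor type 4 (Homo sapiens), read by calcium flux, with a stated time of 25 min (a lower number here means that less compound is needed, a higher number that more compound is needed for the effect), compound 1 gives the limit > 30000 nM.
Compound 2 `C[C@@H]1CN(c2cccc3c2C[C@H](CN(C)[C@H]2CCCc4cccnc42)NC3)C[C@H](C)N1`: in this assay compound 2 gives the limit > 30000 nM.
Compound 3 `CN1CCN(c2cccc3c2C[C@H](CN(C)[C@H]2CCCc4cccnc42)NC3)CC1`: in this assay compound 3 gives the limit > 30000 nM.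

Compound 3 therefore stands at a limit of this assay, not at a number, and all three values sit there (the limit of > 30000 nM in this assay, at which 3 of the 3 values shown sit). Compound 4 `C[C@@H]1CN(c2cccc3c2C[C@H](CN(C)[C@H]2CCCc4cccnc42)NC3)C[C@H](C)N1C` differs from compound 3 by 3,4,5-trimethylpiperazin-1-yl in place of 4-methylpiperazin-1-yl on an aromatic carbon. The measured steps that bear on this change are a step that the two limits leave unreadable from compound 1 to compound 2, a step that the two limits leave unreadable from compound 1 to compound 3 and a step that the two limits leave unreadable from compound 2 to compound 3; none of them has a readable size, so no direction beyond the scatter can be read for this assay. Compound 4 is therefore expected to give 30000 nM in this assay, within 10000 nM and 100000 nM, which means an expected step of a number no higher from compound 3 to compound 4 (the limit leaves the size open).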

Compound 4, half-maximal effective concentration: > 30000 nM
Compound 4: a limit, no number; the forecaster's own chance of this, stated with the estimate: 85%; the middle value sits exactly at the limit.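

In this assay compound 4 gives the limit > 30000 nM and no number. Its steps from compound 1, compound 2 and compound 3 therefore cannot be read: the limit of > 30000 nM in this assay, at which 4 of the 4 values shown sit.

The compounds shown leave open how the piperazine groups on the aromatic carbon compare in size of effect.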